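From Methyl to Nitro: Estimating Compound 3

This account rests on a few compounds, and the source may have more. Where it says the series, first, only, none or still open, it means among the compounds named here.

Measured compounds:
compound 1, `O=C(O)c1ccc(NC(=O)[C@@H]2CCCN2S(=O)(=O)c2ccccc2)cc1`: 26.3%
compound 2, `Cc1ccc(S(=O)(=O)N2CCC[C@H]2C(=O)Nc2ccc(C(=O)O)cc2)cc1`: 31.5%

Both were tested in a functional assay on the whole organism for inhibition, with Rattus norvegicus as the target, read by paw edema, with a stated time of 1 h, at a dose of 100 mg/kg by the oral route; on this read-out lower numbers stand for less inhibition and higher numbers for more inhibition at the one dose given (going by the name of the read-out). Compound 2 gives 31.5% and compound 1 gives 26.3%; the two differ only by a methyl in place of a hydrogen on an aromatic carbon, and that step, a number 5.2 percentage points higher from compound 1 to compound 2 (within the scatter), lies within the scatter, so the two values cannot be told apart.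

The unmeasured compound 3, `O=C(O)c1ccc(NC(=O)[C@@H]2CCCN2S(=O)(=O)c2ccc([N+](=O)[O-])cc2)cc1`, differs from compound 2 by nitro in place of methyl on an aromatic carbon. Cut one bond further out, the change reads 4-methylphenyl to 4-nitrophenyl, at a position para to a large group.

Among the measured compounds shown here, no measured step involves a nitro group, so the only bearing comes from compound 1 and compound 2, whose step a number 5.2 percentage points higher from compound 1 to compound 2 (within the scatter) shows that a change on this aromatic carbon left the number within the scatter. No step beyond the scatter is therefore expected in this assay.

Compound 3 is expected to give about 30%, in a range from 15% to 45%. This expectation amounts to a step of a number 1.5 percentage points lower from compound 2 to compound 3 (within the scatter), which is expected to remain within the scatter.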

Compound 3, a percentage reported as inhibition, in the whole organism at one dose (the size of the read-out at that dose, not a potency): 45.9%
For compound 3 the middle estimate is 15.9 percentage points below the measured one; the measured number lies above the stated range.
By their numbers in this assay, from the lowest: compounds 1 and 2 (each within the scatter of the next); then compound 3.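

In this assay, the aromatic carbon para to a large group turns out to be sensitive to what it carries: the earlier hydrogen-to-methyl change stayed within the scatter, whereas the change from methyl to nitro gives a number 14.4 percentage points higher from compound 2 to compound 3 (beyond the scatter) in this series. Measured against the plain hydrogen, the nitro group gives a number 19.6 percentage points higher from compound 1 to compound 3 (beyond the scatter) on the same carbon, so compound 3 stands clearly above both of the other compounds. A change at this one place on the shared core can therefore move the read-out beyond the scatter, although nothing shown here accounts for why nitro does this when methyl does not.

These three compounds cannot show whether the rise belongs to nitro itself or would also appear with another group on the same carbon, such as an amine, a nitrile or a carboxylic acid. They also leave open whether nitro would behave the same way on a different carbon of this ring, and, with only one dose and one time given, how the compounds would compare at other doses or times.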